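The source may report more compounds than this note shows. Statements on the series, on what has been measured and on what is new or still open speak of the compounds shown alone.

Measured so far in a functional assay on DWD cells (Homo sapiens) for inhibition, read by sulforhodamine B assay (on this read-out higher numbers stand for weaker inhibition of growth and lower numbers for stronger inhibition of growth), are three compounds:

compound 1 `Cc1ccc2[nH]c(-c3ccc(-c4ccc(-c5ccc(N(C)C)cc5)cc4)cc3)nc2c1` gives 3230 nM
compound 2 `FC(F)(F)c1ccc(-c2ccc(-c3ccc(-c4nc5ccccc5[nH]4)cc3)cc2)cc1` gives 100000 nM
compound 3 `Cc1ccc2[nH]c(-c3ccc(-c4ccc(-c5ccccc5)cc4)cc3)nc2c1` gives 28300 nM

Compound 3 stands in the middle of these numbers, with compound 2 higher and compound 1 lower, both gaps beyond the scatter. Compound 4 `Cc1ccc2[nH]c(-c3ccc(-c4ccc(-c5ccc(C(F)(F)F)cc5)cc4)cc3)nc2c1` has trifluoromethyl in place of hydrogen on an aromatic carbon, para to a large group, and the change counts as trifluoromethyl in place of hydrogen on an aromatic carbon in full.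

Within the data shown here, one measured step concerns that same carbon, with hydrogen in place of dimethylamino, and it shows that the number can respond to a change there: an 8.8-fold higher number from compound 1 to compound 3 (0.94 log units; beyond the scatter) is its size. It says nothing directly about trifluoromethyl. Compound 2 carries trifluoromethyl too, on a core that is not the same, and compound 2 gives 100000 nM as the highest number. A small move toward weaker inhibition therefore seems likely, and the expected step is a 1.6-fold higher number from compound 3 to compound 4 (0.20 log units; within the scatter) in this assay for now. For compound 4 the estimated value is 45000 nM, with an expected range from 15000 nM to 100000 nM as the likely span.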

Compound 4, concentration for 50% growth inhibition: 38200 nM
Compound 4: the middle estimate sits 1.2-fold (0.07 log units) above what was measured; the range from low to high includes it.
By their numbers in this assay, from the lowest: compound 1; then compounds 3 and 4 (each within the scatter of the next); then compound 2.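

In this assay, trifluoromethyl in place of hydrogen on this carbon gives a 1.3-fold higher number from compound 3 to compound 4 (0.13 log units; within the scatter) and so does not separate the two groups, whereas trifluoromethyl in place of dimethylamino gives a 12-fold higher number from compound 1 to compound 4 (1.07 log units; beyond the scatter) on the same core. Of the three groups now seen on this carbon, only dimethylamino gives a number clearly apart from the other two, so this position does not respond to every change made there. With trifluoromethyl kept in place, methyl in place of hydrogen on an aromatic carbon of the core of compound 2 gives a 2.6-fold lower number from compound 2 to compound 4 (0.42 log units; beyond the scatter) and shows that the core also affects the number.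

Nothing given here explains any of these steps. From the compounds shown here alone, whether another amine, a carboxylic acid or a longer chain on this carbon would give a number like that of dimethylamino or like that of hydrogen remains open.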